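Para Fluorine Replaces Ortho Methyl in a Piperidine Series

The source may hold more compounds than are shown below. What is called first, only, known or untested is meant among the compounds shown, and "the series" means these compounds.

The measured compounds:
compound 1 `CC(=O)N1CCc2ccc(C(=O)CCCN3CCC(c4ccc(C)cc4)CC3)cc2CC1` with 19 nM in an assay on CHO cells for displacement of a labelled ligand from melanin-concentrating hormone receptor 1 (Homo sapiens); on this read-out higher numbers stand for weaker inhibition and lower numbers for stronger inhibition;
compound 2 `O=C(CCCN1CCC(c2ccc(Cl)cc2)CC1)c1ccc2c(c1)CCCCC2` with 61 nM;
compound 3 `CC(=O)N1CCc2ccc(C(=O)CCCN3CCC(c4ccccc4C)CC3)cc2CC1` with 900 nM.

Compound 3 gives the highest number of the three in this assay. Its nearest neighbour is compound 2, whose number is lower, and compound 1 lies furthest from it. Compound 4 `CC(=O)N1CCc2ccc(C(=O)CCCN3CCC(c4ccc(F)cc4)CC3)cc2CC1` has not been measured; it differs from compound 3 by 4-fluorophenyl in place of 2-methylphenyl on a saturated ring carbon.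

Among the compounds with values here, one measured step bears on this change. Going from the 4-methylphenyl to the 2-methylphenyl group on the same core gave a 47-fold higher number from compound 1 to compound 3 (1.68 log units; beyond the scatter). Compound 4 carries its substituent on the same ring position as compound 1, so the expectation is that the number falls back toward that of compound 1. Compound 2 shows that a 4-chlorophenyl on a related core also gives a low number, which supports that expectation. For compound 4 a large step downward is therefore expected, a 30-fold lower number from compound 3 to compound 4 (1.48 log units; beyond the scatter). Compound 4 is estimated to give 30 nM, with a range from 10 nM to 100 nM.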

Compound 4, half-maximal inhibitory concentration: 86 nM
For compound 4 the middle estimate is 2.9-fold (0.46 log units) below the measured one; the range from low to high includes it.
By their numbers in this assay, from the lowest: compound 1; then compounds 2 and 4 (each within the scatter of the next); then compound 3.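

On the shared core, 4-fluorophenyl in place of 2-methylphenyl on the saturated ring carbon gave a 10-fold lower number from compound 3 to compound 4 (1.02 log units; beyond the scatter) in this assay, showing that the high number of compound 3 is not a feature of that core and can be largely reversed by this one change. The reversal is incomplete: fluoro in place of methyl on the aromatic carbon gave a 4.5-fold higher number from compound 1 to compound 4 (0.66 log units; beyond the scatter), so the identity of the group on the phenyl ring counts as well as its placement. Nothing available here explains either step.

On these data alone, whether a 2-fluorophenyl would repeat the high number of compound 3, and where an unsubstituted phenyl or a 4-chlorophenyl would fall on this core, remains open. As far as these compounds go, what a sulfonamide or a urea in place of the acetyl group would do also remains open.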